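An isobutyl for an isopropyl in compound 3

The source may hold more compounds than are shown below. What is called first, only, known or untested is meant among the compounds shown, and "the series" means these compounds.

Measured values in a physicochemical assay for lipophilicity (a lower number here means a more polar compound, a higher number a more lipophilic compound), so far
Compound 1 `Cc1nc(C)c(C(=O)N[C@H](CC(C)C)C(=O)Oc2ccc(-c3cc(=O)c4c(O)c(O)c(O)cc4o3)cc2)nc1C` at 0.91
Compound 2 `Cc1nc(C)c(COC(=O)N[C@@H](C(=O)Oc2ccc(-c3cc(=O)c4c(O)c(O)c(O)cc4o3)cc2)C(C)C)nc1C` at 1.04

Compound 2 stands at 1.04 and compound 1 at 0.91 with the two values within the scatter of each other. Compound 3 `Cc1nc(C)c(COC(=O)N[C@H](CC(C)C)C(=O)Oc2ccc(-c3cc(=O)c4c(O)c(O)c(O)cc4o3)cc2)nc1C` shares the core of compound 2 and carries isobutyl in place of isopropyl on a saturated chain carbon bound to an amide-type nitrogen and a carbonyl carbon. Within the data shown here, no measured pair shows this change, so the expectation rests on the structural change alone and on compound 2 at 1.04 as the starting value. In this assay a small upward step is expected, estimated as a number 0.26 log units higher from compound 2 to compound 3 (within the scatter) in size, near the edge of the scatter. Compound 3 is therefore expected at 1.3 within an estimated range of 1 to 1.6 once measured.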

Compound 3, partition coefficient: 1.69
Estimate against measurement, compound 3: 0.39 log units below; measured number above the stated range.
By their numbers in this assay, from the lowest: compounds 1 and 2 (each within the scatter of the next); then compound 3.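

In this assay, isobutyl in place of isopropyl on a saturated chain carbon bound to an amide-type nitrogen and a carbonyl carbon gives a number 0.65 log units higher from compound 2 to compound 3 (beyond the scatter) and thereby shows that the read-out responds to this change at this position by more than the scatter. With isobutyl present in both compounds, (3,5,6-trimethylpyrazin-2-yl)methoxy in place of 3,5,6-trimethylpyrazin-2-yl on a carbonyl carbon gives a number 0.78 log units higher from compound 1 to compound 3 (beyond the scatter) and shows that this second position also moves the number beyond the scatter. Nothing measured here accounts for the size of either step.

On these data alone, each change is seen in one pair only, so whether either step would carry over to another member of the series remains open. How a longer chain or an amine at the saturated chain carbon would read in this assay also stays unresolved.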